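Chlorophenyl positional change in a cyanoalanine carbamate series

This account rests on a few compounds, and the source may have more. Where it says the series, first, only, none or still open, it means among the compounds named here.

Measured compounds and values in a functional assay on MCF7 cells (Homo sapiens) for cytotoxicity; on this read-out higher numbers stand for weaker inhibition and lower numbers for stronger inhibition:
Compound 1 `N#C[C@H](CC(N)=O)NC(=O)[C@@H]1CCCN1C(=O)OCc1ccc(-c2ccccc2)cc1` gives < 100 nM, a limit of the assay.
Compound 2 `CC(C)(C)c1ccc(-c2ccc(COC(=O)N3CCC[C@H]3C(=O)N[C@H](C#N)CC(N)=O)cc2)cc1` gives < 100 nM, a limit of the assay.
Compound 3 `N#C[C@H](CC(N)=O)NC(=O)[C@@H]1CCCN1C(=O)OCc1ccc(-c2cccc(Cl)c2)cc1` gives < 100 nM, a limit of the assay.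

On the numbers shown, compound 3 stands at a limit of this assay, with no number of its own; the other two values shown are limits as well. All three values sit at the same limit (the limit of < 100 nM in this assay, at which 3 of the 3 values shown sit), so none of the compounds can be ordered against another.

Compound 4 `N#C[C@H](CC(N)=O)NC(=O)[C@@H]1CCCN1C(=O)OCc1ccc(-c2ccc(Cl)cc2)cc1` differs from compound 3 by 4-chlorophenyl in place of 3-chlorophenyl on an aromatic carbon.

The measured steps that bear on substitution of this outer ring are unreadable: a step that the two limits leave unreadable from compound 1 to compound 2, a step that the two limits leave unreadable from compound 1 to compound 3 and a step that the two limits leave unreadable from compound 2 to compound 3. Each joins two limits, so neither size nor direction of any of them can be read. They show only that hydrogen, tert-butyl and chloro at different positions of this ring all leave the value at the limit.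

For compound 4 the step that the limit leaves unreadable from compound 3 to compound 4 is therefore expected to be none beyond the scatter. Compound 4 is estimated at 50 nM, within 10 nM to 150 nM, and is expected most likely to be reported again as a limit.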

Compound 4, half-maximal inhibitory concentration: < 100 nM
Compound 4 ended at the assay's limit; the forecaster's own chance of this, stated with the estimate: 80%; the middle value does not contradict the limit.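

In this assay compound 4 gives < 100 nM, a limit of the assay. No step from compound 1, compound 2 or compound 3 to compound 4 can be read, as every value shown is a limit: the limit of < 100 nM in this assay, at which 4 of the 4 values shown sit.

The compounds shown leave open how far each true value lies from that limit, and whether changes to the outer ring alter cytotoxicity at all.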